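Swapping a pivaloyl amide for a propyl urea

The compounds below may be only part of what the source reports. "The series", "measured", "known", "first", "only" and "open" are said of these compounds alone.

Three sulfonate esters have been measured in a functional assay on M21 cells (Homo sapiens) for antiproliferative activity, read by sulforhodamine B assay, with a stated time of 48 h; a higher number here means a weaker inhibitor, a lower number a stronger inhibitor. Compound 1, `CCC(=O)Nc1ccc(S(=O)(=O)Oc2ccccc2I)cc1`, gives 11000 nM. Compound 2, `CC(C)c1ccccc1OS(=O)(=O)c1ccc(NC(=O)C(C)(C)C)cc1`, gives 6200 nM. Compound 3, `CC(C)(C)C(=O)Nc1ccc(S(=O)(=O)Oc2ccccc2I)cc1`, gives 8300 nM, a number that sits among the other two, with every gap inside the scatter: a 1.3-fold lower number from compound 1 to compound 3 (0.12 log units; within the scatter), and a 1.3-fold higher number from compound 2 to compound 3 (0.13 log units; within the scatter).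

Compound 4, `CCCNC(=O)Nc1ccc(S(=O)(=O)Oc2ccccc2I)cc1`, keeps the whole frame of compound 3 and changes only the amide cap: propylamino in place of tert-butyl on a carbonyl carbon. Neither measured step resembles this change, and the two that exist, one on the carbonyl carbon and one on the aromatic carbon, both stayed inside the scatter. Nothing in these numbers points to a move in either direction, so the expectation for this assay is a 1.1-fold higher number from compound 3 to compound 4 (0.04 log units; within the scatter), a step that does not clear the scatter. Compound 4 is therefore estimated at 9000 nM, with a plausible range from 3000 nM to 27000 nM.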

Compound 4, half-maximal inhibitory concentration: 5400 nM
Compound 4: the middle estimate sits 1.7-fold (0.22 log units) above what was measured, and the stated range covers the measured number.
By their numbers in this assay, from the lowest: compounds 4, 2, 3 and 1 (each within the scatter of the next, the first and the last beyond it).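

On this carbonyl carbon, propylamino brings in a hydrogen-bond donor that tert-butyl lacks, yet in this assay the change gives a 1.5-fold lower number from compound 3 to compound 4 (0.19 log units; within the scatter) and so cannot be told apart from no change. Measured against the ethyl group of compound 1, however, the same position gives a 2.0-fold lower number from compound 1 to compound 4 (0.31 log units; beyond the scatter), a modest step and the first in this set to clear the scatter, which shows that a change here can register in this assay. No available evidence gives a reason for this step.

Whether that step follows the urea nitrogen or the propyl chain remains open, as compound 4 is the only urea shown. A butylamino or dimethylamino group on the same carbonyl carbon would help separate the two, and pairing propylamino with the isopropyl group of compound 2 is also an open question.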